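This account rests on a few compounds, and the source may have more. Where it says the series, first, only, none or still open, it means among the compounds named here.

Measured compounds:
- compound 1 `Nc1cc(N)c2nc(-c3ccccc3)c(Oc3ccc(Cl)c(Cl)c3)nc2c1`: 13500 nM
- compound 2 `CCOC(=O)[C@H](CCC(=O)O)NC(=O)c1ccc(CNc2nc3cc(N)cc(N)c3nc2-c2ccccc2)cc1`: < 100000 nM
- compound 3 `Nc1cc(N)c2nc(-c3ccccc3)c(NCc3ccc(Cl)c(Cl)c3)nc2c1`: 4570 nM

In a functional assay on SF-539 cells (Homo sapiens) for inhibition, read by sulforhodamine B assay, with a stated time of 48 h (on this read-out lower numbers stand for stronger inhibition of growth and higher numbers for weaker inhibition of growth), compound 3 gives 4570 nM, the lower of the two numbers that were measured outright; compound 1 gives the nearest value, and it is higher by a margin beyond the usual scatter. For compound 2 the result < 100000 nM is a limit of the assay rather than a number (the limit of < 100000 nM in this assay, at which 1 of the 3 values shown sits). Compound 4 `COc1ccc(CNc2nc3cc(N)cc(N)c3nc2-c2ccccc2)cc1OC` differs from compound 3 in one place: 3,4-dimethoxyphenyl in place of 3,4-dichlorophenyl on a saturated chain carbon bound to a nitrogen on an aromatic ring. Within the data shown here, no pair of measured compounds shows what this exchange does. The step of a 2.2-fold higher number from compound 3 to compound 4 (0.34 log units; beyond the scatter) is therefore only an estimate, resting on the structural change and on how far the known numbers spread. A modest weakening beyond the scatter is expected, though a result within the scatter of compound 3 cannot be ruled out. Compound 4 is therefore expected to give about 10000 nM, with a plausible range from 3000 nM to 40000 nM.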

Compound 4, concentration for 50% growth inhibition: 20000 nM
Estimate against measurement, compound 4: 2.0-fold (0.30 log units) below, within the range that was stated.
By their numbers in this assay, from the lowest: compound 3; then compounds 1 and 4 (each within the scatter of the next).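

In this assay, replacing 3,4-dichlorophenyl with 3,4-dimethoxyphenyl on a saturated chain carbon bound to a nitrogen on an aromatic ring gives a 4.4-fold higher number from compound 3 to compound 4 (0.64 log units; beyond the scatter). Among these compounds, this is the first measured exchange at this place, and it shows that growth inhibition responds to what the ring carries: the six-membered aromatic ring stays, the two chlorine atoms give way to two methoxy groups, and inhibition weakens. Nothing shown here gives a reason for this weakening.

A single exchange cannot separate a gain from the chlorine atoms from a loss caused by the methoxy groups. It also leaves open how growth inhibition would respond to other groups in their stead, such as trifluoromethyl or a nitrile.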